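Acyl variation on the shared core: compound 4

This account rests on a few compounds, and the source may have more. Where it says the series, first, only, none or still open, it means among the compounds named here.

Measured so far in an assay on LtK cells with ATP-sensitive inward rectifier potassium channel 11 (Homo sapiens) as the target; on this read-out higher numbers stand for an effect only at larger amounts of compound and lower numbers for an effect already at smaller amounts:
compound 1 `O=C(CC1CCCC1)Nc1c(C(O)(C(F)(F)F)C(F)(F)F)ccc2ccccc12`, giving 81 nM
compound 2 `O=C(NCCCCCCCl)Nc1c(C(O)(C(F)(F)F)C(F)(F)F)ccc2ccccc12`, giving 4840 nM
compound 3 `O=C(Nc1c(C(O)(C(F)(F)F)C(F)(F)F)ccc2ccccc12)c1ccccc1`, giving 44 nM

Compound 3 has the lowest of the three numbers; its nearest neighbour is compound 1, a 1.8-fold lower number from compound 1 to compound 3 (0.27 log units; within the scatter), and its furthest is compound 2, a 110-fold lower number from compound 2 to compound 3 (2.04 log units; beyond the scatter). Compound 4 `O=C(Nc1c(C(O)(C(F)(F)F)C(F)(F)F)ccc2ccccc12)c1ccc(C(F)(F)F)cc1` differs from compound 3 by trifluoromethyl in place of hydrogen on an aromatic carbon. For the measured compounds named here, no measured step alters a substituent on that phenyl; the measured steps exchange the whole group on the carbonyl carbon, where phenyl and cyclopentylmethyl stand within the scatter of each other while (6-chlorohexyl)amino sits far off, as a 60-fold higher number from compound 1 to compound 2 (1.78 log units; beyond the scatter) shows. A substituent on the phenyl is therefore expected to give no step beyond the scatter, a 1.1-fold lower number from compound 3 to compound 4 (0.04 log units; within the scatter). Compound 4 is estimated at 40 nM, range 12 nM to 130 nM.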

Compound 4, half-maximal effective concentration: 160 nM
For compound 4 the middle estimate is 4.0-fold (0.60 log units) below the measured one; measured number outside the range, above it.
By their numbers in this assay, from the lowest: compounds 3, 1 and 4 (each within the scatter of the next, the first and the last beyond it); then compound 2.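

In this assay, the aromatic carbon para to a large group is not a neutral place for substitution: trifluoromethyl in place of hydrogen gives a modest step (a 3.6-fold higher number from compound 3 to compound 4 (0.56 log units; beyond the scatter)). The 4-(trifluoromethyl)phenyl group stays within the scatter of cyclopentylmethyl (a 2.0-fold higher number from compound 1 to compound 4 (0.30 log units; within the scatter)) and remains far from (6-chlorohexyl)amino (a 30-fold lower number from compound 2 to compound 4 (1.48 log units; beyond the scatter)). Nothing at hand accounts for the step on the phenyl. Going by these compounds, whether that step is specific to trifluoromethyl remains open. A single fluorine, a methoxy group or an amine on the same carbon would test this.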